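Benzyl to acetyl on the ring nitrogen: cytotoxicity notes

The source may hold more compounds than are shown below. What is called first, only, known or untested is meant among the compounds shown, and "the series" means these compounds.

Compound 2 `Cc1cc(C)cc(Cn2c(=O)cc(NCc3ccccc3)n(Cc3ccccc3)c2=O)c1` reaches only the limit of an ADME assay on MT4 cells (Homo sapiens) for cytotoxicity, read by MTT assay, with a stated time of 4 days (on this read-out lower numbers stand for higher toxicity in this test and higher numbers for lower toxicity in this test), and gives > 100000 nM; this is a limit of the assay, not a number. Compound 1 `Cc1cc(C)cc(Cn2c(=O)cc(N3CCNCC3)n(Cc3ccccc3)c2=O)c1` gives 16000 nM in this assay. Within the data shown here, the single measured step, an at least 6.2-fold higher number from compound 1 to compound 2 (0.79 log units; beyond the scatter), is a lower bound on the true change because of the limit of > 100000 nM in this assay, at which 2 of the 3 values shown sit. Compound 3 `Cc1cc(C)cc(Cn2c(=O)cc(N=[N+]=[N-])n(Cc3ccccn3)c2=O)c1` likewise sits at the limit, giving > 100000 nM in this assay; no step to it is shown.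

Compound 4 `CC(=O)Nc1cc(=O)n(Cc2cc(C)cc(C)c2)c(=O)n1Cc1ccccc1` differs from compound 2 as follows: acetyl in place of benzyl on a nitrogen on an aromatic ring. Among the measured compounds shown here, no measured step bears on this change; the step from compound 1 to compound 2 concerns a different group and sets no direction for it. With compound 2 already at the limit, the expected outcome is that compound 4 stays near that limit, and no step beyond the scatter is expected, so an at least 1.2-fold lower number from compound 2 to compound 4 (0.09 log units; that floor lies within the scatter) is the estimated move. Compound 4 is therefore expected to give about 80000 nM in this assay, estimated between 25000 nM and 150000 nM.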

Compound 4, half-maximal cytotoxic concentration: > 100000 nM
Compound 4 was reported as a limit; the forecaster's own chance of this, stated with the estimate: 60%; middle value at least 1.2-fold (0.09 log units) from the limit.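

In this assay, acetamido in place of piperazin-1-yl on an aromatic carbon gives an at least 6.2-fold higher number from compound 1 to compound 4 (0.79 log units; beyond the scatter), so a second group, after benzylamino, moves the number up to the limit from compound 1. Benzylamino and acetamido therefore share this outcome despite having different sizes, and among the compounds shown only compound 1, with piperazin-1-yl, gives a number that is not a limit. The step from compound 2 to compound 4 cannot be read, and the lower bounds do not give the true size of either step from compound 1: the limit of > 100000 nM in this assay, at which 3 of the 4 values shown sit.

Going by these compounds, how far compound 2 and compound 4 truly differ stays open, as does whether the lower number belongs to piperazin-1-yl alone. A morpholin-4-yl group or a free amino group on the same aromatic carbon would test that.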